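From Methoxy to a Carboxy-Hydroxypropylamino Group

This account rests on a few compounds, and the source may have more. Where it says the series, first, only, none or still open, it means among the compounds named here.

Compound 1 `C=C1[C@H](C)CCC[C@]1(C)CC/C(C)=C/CC1=C(O)C(=O)C=C(OC)C1=O` carries a methoxy group on its core. In an ADME assay on KB cells (Homo sapiens) for cytotoxicity, with a stated time of 48 h (a higher number here means a weaker inhibitor, a lower number a stronger inhibitor), compound 1 gives > 10 ug/mL, which is a limit of the assay rather than a measured number. Compound 3 `CC1=CCC[C@](C)(CC/C(C)=C/CC2=C(O)C(=O)C=C(N[C@H](C(=O)O)[C@H](C)O)C2=O)[C@@H]1C` likewise reaches only a limit, > 10 ug/mL. Compound 2 `CC1=CCC[C@H]2[C@](C)(CC3=C(O)C(=O)C=C(N[C@@H](CO)C(=O)O)C3=O)[C@@H](C)CC[C@]12C` gives 7.6 ug/mL in this assay.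

Compound 4 `C=C1[C@H](C)CCC[C@]1(C)CC/C(C)=C/CC1=C(O)C(=O)C=C(N[C@H](C(=O)O)[C@@H](C)O)C1=O` differs from compound 1 in one place: (1-carboxy-2-hydroxypropyl)amino in place of methoxy on a double-bonded ring carbon. Among the compounds with values here, no step between measured compounds is available, and the values cluster at the limit (the limit of > 10 ug/mL in this assay, at which 2 of the 3 values shown sit), so the measured compounds give no direction for this change. The step from compound 1 to compound 4 is expected to stay within the usual scatter, a step that the limit leaves unreadable from compound 1 to compound 4. Compound 4 is expected to give about 12 ug/mL in this assay, most likely reported again as a limit, within a range from 5 ug/mL to 30 ug/mL.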

Compound 4, half-maximal inhibitory concentration: > 10 ug/mL
Compound 4 gave a limit, no number (the forecaster's own chance of this, stated with the estimate: 65%); the middle value does not contradict the limit.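

No step can be read from compound 1 to compound 4, since both results are limits: the limit of > 10 ug/mL in this assay, at which 3 of the 4 values shown sit.

The compounds shown leave open whether (1-carboxy-2-hydroxypropyl)amino in place of methoxy changes the result in this assay at all.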